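A few compounds are considered here, and "the series" means these few. Any claim that something is new, unique, unknown or untested is made for them only; others in the source may bear on it.

Working notes on the series. In a functional assay on CCRF-CEM cells (Homo sapiens), read by MTT assay, with a stated time of 72 h (a lower number here means a stronger inhibitor, a higher number a weaker inhibitor), compound 1 `O=c1[nH]cnc2c1c(-c1ccoc1)cn2[C@@H]1O[C@H](CO)[C@@H](O)[C@H]1O` gives 9030 nM; compound 2 `CN(C)c1ncnc2c1c(-c1ccoc1)cn2[C@@H]1O[C@H](CO)[C@@H](O)[C@H]1O` gives 13300 nM in this assay; compound 3 `O=c1[nH]cnc2c1c(-c1ccsc1)cn2[C@@H]1O[C@H](CO)[C@@H](O)[C@H]1O` gives 14500 nM in this assay. Compound 3 holds the highest of the three numbers, yet its gaps to compound 2 and to compound 1 both sit within the scatter, so no order among the three can be claimed. Within the data shown here, the one single-point step measured, a 1.6-fold higher number from compound 1 to compound 3 (0.21 log units; within the scatter), was within the scatter. Compound 4 `O=c1[nH]cnc2c1c(-c1cc3ccccc3o1)cn2[C@@H]1O[C@H](CO)[C@@H](O)[C@H]1O` differs from compound 3 by 1-benzofuran-2-yl in place of thiophen-3-yl on an aromatic carbon. Among the measured compounds shown here, no measured step covers a fused two-ring group at this position; the entering group is the larger one, so the spread must be wide. Compound 4 is therefore expected near 15000 nM, within 5000 nM to 45000 nM. The expected step is a 1.0-fold higher number from compound 3 to compound 4 (0.01 log units; within the scatter).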

Compound 4, half-maximal inhibitory concentration: > 20000 nM
Compound 4: only a limit was reported (the forecaster's own chance of this, stated with the estimate: 15%); middle value at least 1.3-fold (0.12 log units) away from the limit.
By their numbers in this assay, from the lowest: compounds 1, 2 and 3 (each within the scatter of the next). At a limit, above all of these: compound 4.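

Swapping furan-3-yl for thiophen-3-yl had produced no step beyond the scatter at this aromatic carbon, but 1-benzofuran-2-yl in place of furan-3-yl gives an at least 2.2-fold higher number from compound 1 to compound 4 (0.34 log units; beyond the scatter). Measured against thiophen-3-yl, the same group gives an at least 1.3-fold higher number from compound 3 to compound 4 (0.13 log units; that floor lies within the scatter), so that comparison alone shows no firm change. In this assay, the value for compound 4, > 20000 nM, is a limit and not a number. The compounds shown leave open how far the step extends, and how a phenyl ring or an amine on this aromatic carbon would read.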